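Pyridyl for fluorophenyl on the oxazole ketone core

The source may hold more compounds than are shown below. What is called first, only, known or untested is meant among the compounds shown, and "the series" means these compounds.

Compound 1: `O=C(CCCCCCc1ccccc1)c1ncc(-c2ccccc2F)o1`, 110 nM in an assay (Rattus norvegicus) for inhibition of Fatty-acid amide hydrolase 1 (Homo sapiens); a higher number here means a weaker inhibitor, a lower number a stronger inhibitor
Compound 2: `NC(=O)c1cccc(-c2cnc(C(=O)CCCCCCc3ccccc3)o2)c1`, 6 nM
Compound 3: `O=C(CCCCCCc1ccccc1)c1ncc(-c2ccc(F)cc2)o1`, 62 nM

Compound 3 sits second highest of the three numbers in this assay. Its nearest neighbour is compound 1, with a 1.8-fold lower number from compound 1 to compound 3 (0.25 log units; within the scatter); its furthest is compound 2, with a 10-fold higher number from compound 2 to compound 3 (1.01 log units; beyond the scatter).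

Compound 4 is `Cc1cccc(-c2cnc(C(=O)CCCCCCc3ccccc3)o2)n1`. It differs from compound 3 in one place: 6-methylpyridin-2-yl in place of 4-fluorophenyl on an aromatic carbon.

Within the data shown here, no measured step exchanges a carbon-only ring for one with a ring nitrogen, so the bearing of the earlier steps is indirect. The step from compound 1 to compound 3 shows that moving a fluorine on that ring changes little (a 1.8-fold lower number from compound 1 to compound 3 (0.25 log units; within the scatter)). The step from compound 2 to compound 3 shows that a ring bearing a hydrogen-bond acceptor gave a large gap (a 10-fold higher number from compound 2 to compound 3 (1.01 log units; beyond the scatter)), though the entering group of compound 4 shares only the counted acceptor with that ring, not the carbamoyl itself. Compound 4 is therefore expected to give a number close to compound 3, with at most a modest shift toward a lower value, an expected step of a 1.6-fold lower number from compound 3 to compound 4 (0.19 log units; within the scatter). The estimate for compound 4 in this assay is 40 nM, within 10 nM to 160 nM.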

Compound 4, inhibition constant: 3.3 nM
Estimate against measurement, compound 4: 12-fold (1.08 log units) above; measured number outside the range, below it.
By their numbers in this assay, from the lowest: compounds 4 and 2 (each within the scatter of the next); then compounds 3 and 1 (each within the scatter of the next).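

In this assay, 6-methylpyridin-2-yl on this aromatic carbon, next to the ring oxygen, takes the series well away from the fluorophenyl compounds, with a large step from the 4-fluorophenyl compound (a 19-fold lower number from compound 3 to compound 4 (1.27 log units; beyond the scatter)) and another from the 2-fluorophenyl compound (a 33-fold lower number from compound 1 to compound 4 (1.52 log units; beyond the scatter)). The step from the carbamoyl compound stays within the scatter (a 1.8-fold lower number from compound 2 to compound 4 (0.26 log units; within the scatter)), so a low number at this position is not tied to the 3-carbamoylphenyl group: a ring with a single methyl and a ring nitrogen, and no carbamoyl, stands level with it. No measurement at hand accounts for why this exchange has so large an effect.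

Because the ring nitrogen and the methyl enter together in compound 4, the compounds shown do not tell how much of the step belongs to each; an unsubstituted pyridin-2-yl and a 3-methylphenyl group would separate them. Also open, as far as these compounds go, is whether the low numbers persist with other groups on the pyridine ring, such as a carboxylic acid, an amine or a longer alkyl chain in place of the methyl.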